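The source may report more compounds than this note shows. Statements on the series, on what has been measured and on what is new or still open speak of the compounds shown alone.

Three compounds of a shared core carry a measurement in a functional assay on DU-145 cells (Homo sapiens) for inhibition, read by MTT assay, with a stated time of 24 h (on this read-out lower numbers stand for stronger inhibition and higher numbers for weaker inhibition), and a fourth awaits one. Compound 1, `CCOC(=O)C1=Cc2ccccc2OC1(OCc1cc(-c2ccc(F)cc2F)no1)C(F)(F)F`, gives only a limit: in this assay compound 1 reads > 150000 nM, which is a limit of the assay and not a number. Compound 3, `CCOC(=O)C1=Cc2ccccc2OC1(OCc1cc(-c2ccc(C)cc2)no1)C(F)(F)F`, likewise gives in this assay the limit > 150000 nM. The step that the two limits leave unreadable from compound 1 to compound 3 therefore cannot be read. Among the measured compounds shown here, compound 2, `CCOC(=O)C1=Cc2ccccc2OC1(OCc1cn(CC(=O)Nc2cccc(Cl)c2)nn1)C(F)(F)F`, stands apart as the only member with a number: in this assay compound 2 gives 10100 nM. Of the three values, two sit at the limit of > 150000 nM in this assay, at which 2 of the 3 values shown sit.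

The unmeasured compound 4, `CCOC(=O)C1=Cc2ccccc2OC1(OCc1cn(CC(=O)Nc2ccc(C)cc2)nn1)C(F)(F)F`, differs from compound 2 in a single place: 4-methylphenyl in place of 3-chlorophenyl on an amide-type nitrogen. For the measured compounds named here, no measured step touches this position, and the one step that exchanges an aryl group elsewhere on the core, from compound 1 to compound 3, lies between two limits and gives no size. The change is expected to move the value of compound 4 little, if at all, beyond the scatter, so the step of a 1.2-fold higher number from compound 2 to compound 4 (0.07 log units; within the scatter) from compound 2 to compound 4 is estimated as small. Compound 4 is accordingly expected to give about 12000 nM, with a range from 3000 nM to 60000 nM, in this assay.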

Compound 4, half-maximal inhibitory concentration: > 150000 nM
Compound 4: no number, only a limit (the forecaster's own chance of this, stated with the estimate: 20%); middle value at least 12-fold (1.09 log units) away from the limit.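

In this assay the aryl group on the amide-type nitrogen proves able to carry a large change: 4-methylphenyl in place of 3-chlorophenyl gives an at least 14-fold higher number from compound 2 to compound 4 (1.17 log units; beyond the scatter), the only step among the compounds shown that has a readable size. Compound 4 gives a limit of the assay and not a number, and it joins the other compounds that stand at such a limit: the limit of > 150000 nM in this assay, at which 3 of the 4 values shown sit. Among the compounds shown here, compound 2, with its 3-chlorophenyl group, therefore remains the only member with a number, and this one exchange on the amide-type nitrogen is enough to separate a measurable value from a limit.

The exchange alters both the substituent and its printed place on the phenyl ring, so the compounds shown leave open whether the chlorine, the methyl group or the place accounts for the step, a question that a 4-chlorophenyl or a 3-methylphenyl group on the same nitrogen would address. They also leave open how an unsubstituted phenyl group, or a phenyl group carrying an amine or a carboxylic acid, would read at this position.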